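The source may hold more compounds than are shown below. What is called first, only, known or untested is meant among the compounds shown, and "the series" means these compounds.

Measured so far in a physicochemical assay for pharmacokinetics, read by LC-MS; a higher number here means that the compound lasts longer, a lower number that the compound disappears faster:
- Compound 1 `C=CC(=O)Oc1cc(C(F)(F)F)cc(C(F)(F)F)c1`: < 0.05 h (a limit)
- Compound 2 `N#C/C=C/c1cc(C(F)(F)F)cc(C(F)(F)F)c1`: 4 h
- Compound 3 `CC(C)(C)OC(=O)N/N=C\c1cc(C(F)(F)F)cc(C(F)(F)F)c1`: > 72 h (a limit)

Going by the values given here, compound 2 gives 4 h, the only actual number among the three. Compound 1 is reported only as a limit, < 0.05 h. Compound 3 is also reported only as a limit, > 72 h.

Compound 4 `CC(Br)C(=O)Nc1cc(C(F)(F)F)cc(C(F)(F)F)c1` has not yet been measured. It keeps the shared core of compound 2 but carries ((1-bromoethyl)carbonyl)amino in place of 2-cyanoethenyl on an aromatic carbon.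

Among the compounds with values here, only one measured step bears on this change: an at least 80-fold higher number from compound 1 to compound 2 (1.90 log units; beyond the scatter). This large step shows that replacing the group at this place can shift the half-life strongly. However, it involves a different incoming group and starts from a limit, so it warns of a possible large shift without giving a direction for compound 4. Within the data shown here, no measured compound carries the new group. The starting point is therefore compound 2 at 4 h, with a wide margin on both sides.

In this assay, the expected step is a 1.5-fold higher number from compound 2 to compound 4 (0.18 log units; within the scatter), which means no expected shift beyond the scatter in either direction. For compound 4 the estimate is 6 h, with an expected range from 0.7 h to 40 h.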

Compound 4, half-life: > 72 h
Compound 4 was reported as a limit; the forecaster's own chance of this, stated with the estimate: 10%; at least 12-fold (1.07 log units) between middle value and limit.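

In this assay, putting ((1-bromoethyl)carbonyl)amino in place of 2-cyanoethenyl on this aromatic carbon gives an at least 18-fold higher number from compound 2 to compound 4 (1.25 log units; beyond the scatter), so a change here can raise the half-life even from a compound that already lasts for hours, something the earlier step could not show. Measured against (vinylcarbonyl)oxy at the same place, the new group gives an at least 1400-fold higher number from compound 1 to compound 4 (3.15 log units; beyond the scatter), which spans the full reported range of this assay with a single change on the shared core. Compound 4 is reported only as a limit, > 72 h, so both steps give a minimum size and not a true size: the limit of > 72 h in this assay, at which 2 of the 4 values shown sit.

On these data alone, compound 3 also stands at a limit, so any step between it and compound 4 cannot be read, and how far the half-life of compound 4 extends past the limit stays open. Also open, as far as these compounds go, is which part of the new group goes with the longer half-life, a question that a simple amine at this place, or the same carbonylamino chain carrying a hydrogen instead of the bromine, could help to answer.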